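The compounds below may be only part of what the source reports. "The series", "measured", "known", "first", "only" and "open" are said of these compounds alone.

Of the compounds shown here, three have been measured in a functional assay on NCI-H460 cells (Homo sapiens) for cytotoxicity, read by MTT assay, with a stated time of 72 h; a lower number here means a stronger inhibitor, a higher number a weaker inhibitor. Compound 1 `O=Cc1cn(Cc2ccc(Cl)cc2)c2ccccc12` gives 850 nM. Compound 2 `CCN(CC)Cc1ccc2nc(NC(=O)N/N=C/c3cn(Cc4ccccc4Cl)c4ccccc34)sc2c1` gives 980 nM, and compound 3 `CCN(CC)Cc1ccc2nc(NC(=O)N/N=C/c3c[nH]c4ccccc34)sc2c1` gives 3140 nM. Among these three numbers compound 2 stands second highest; its nearest neighbour is compound 1, a gap within the scatter, and its furthest is compound 3, a gap that lies beyond the scatter. Among the measured compounds shown here, the only step between compounds differing in one place is a 3.2-fold higher number from compound 2 to compound 3 (0.51 log units; beyond the scatter), a modest change. Compound 4 `CC1CCN(Cc2ccc3nc(NC(=O)N/N=C/c4cn(Cc5ccccc5Cl)c5ccccc45)sc3c2)CC1` has not yet been measured. It differs from compound 2 in one place: 4-methylpiperidin-1-yl in place of diethylamino on a saturated chain carbon bound to an aromatic carbon. For the measured compounds named here, no measured step touches the diethylamino group; the step from compound 2 to compound 3 concerns the aromatic nitrogen instead, so it gives no direct guide. With nothing in the measured steps pointing either way, the expected step of a 1.0-fold higher number from compound 2 to compound 4 (0.01 log units; within the scatter) is none beyond the scatter. Compound 4 is therefore estimated at 1000 nM, with a range from 400 nM to 2500 nM.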

Compound 4, half-maximal inhibitory concentration: 1080 nM
Estimate against measurement, compound 4: 1.1-fold (0.03 log units) below; the range from low to high includes it.
By their numbers in this assay, from the lowest: compounds 1, 2 and 4 (each within the scatter of the next); then compound 3.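

In this assay, the exchange at the end of the side chain gives a 1.1-fold higher number from compound 2 to compound 4 (0.04 log units; within the scatter), so the two numbers cannot be told apart. At this position, a saturated chain carbon bound to an aromatic carbon, the ring-bearing 4-methylpiperidin-1-yl group can therefore stand in place of the open-chain diethylamino group with no measurable difference in this assay. Among the compounds shown here, the earlier step concerned only the aromatic nitrogen, so this is the first reading at the amine end of the molecule, and no supporting data here explain the result.

As far as these compounds go, whether a morpholine ring, a primary amine or a carboxylic acid at this position would keep the number in the same range remains open. From the compounds shown here alone, it is also open whether 4-methylpiperidin-1-yl would read the same way with hydrogen in place of 2-chlorobenzyl on the aromatic nitrogen.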